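The compounds below may be only part of what the source reports. "The series", "measured", "known", "first", "only" and "open" are said of these compounds alone.

Of the compounds shown here, two of the same core have been measured in a functional assay on HL-60 cells (Homo sapiens) for antiproliferative activity, with a stated time of 24 h; on this read-out lower numbers stand for stronger inhibition and higher numbers for weaker inhibition. Compound 1 `NC(=O)c1c(NC(=O)c2ccccc2Br)sc2c1CCN(C(=S)Nc1ccccc1Cl)C2` gives 14600 nM, which is the lower of the two numbers seen. Compound 2 `NC(=O)c1c(NC(=O)c2ccc(C(F)(F)F)cc2)sc2c1CCN(C(=S)Nc1ccccc1Cl)C2` gives 36100 nM. Compound 2 differs from compound 1 only in the group on a carbonyl carbon, and this change brings a 2.5-fold higher number from compound 1 to compound 2 (0.39 log units; beyond the scatter).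

Compound 3 `NC(=O)c1c(NC(=O)c2ccccc2Br)sc2c1CCN(C(=S)Nc1ccccc1Br)C2` is the next compound to be considered. Relative to compound 1 its change is bromo in place of chloro on an aromatic carbon. For the measured compounds named here, this is a different place from the one varied between compound 1 and compound 2, and it swaps one halogen for another rather than changing a whole aryl group, so the one measured step offers only a loose guide: it shows that the numbers can move by a modest amount when a ring substituent changes. Going by the values given here, with no step of the same kind available, a change of this sort is expected to give no difference beyond the scatter, or at most a small one in either direction. Compound 3 is therefore estimated at 13000 nM, within a range from 5000 nM to 35000 nM, which means an expected step of a 1.1-fold lower number from compound 1 to compound 3 (0.05 log units; within the scatter).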

Compound 3, half-maximal inhibitory concentration: 17600 nM
The estimate for compound 3 lay 1.4-fold (0.13 log units) below the measured number; measured number inside the range.
By their numbers in this assay, from the lowest: compounds 1 and 3 (each within the scatter of the next); then compound 2.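

In this assay, the swap of chloro for bromo on this aromatic carbon, ortho to a large group, gives a 1.2-fold higher number from compound 1 to compound 3 (0.08 log units; within the scatter), so the assay does not tell the 2-chlorophenyl and 2-bromophenyl versions apart. For the compounds shown here, this is the first look at this second place on the shared core, since the only earlier comparison changed the group on a carbonyl carbon and gave a 2.5-fold higher number from compound 1 to compound 2 (0.39 log units; beyond the scatter); here, one halogen can stand in for the other with no change that can be read. No measurement at hand speaks to what lies behind this result.

From the compounds shown here alone, both compounds carry a halogen at this place, so it remains open whether the number would hold with plain hydrogen, a methyl group, a methoxy group or an amine on the same aromatic carbon. Going by these compounds, it is also open whether the two halogens would still read alike with the 4-(trifluoromethyl)phenyl group of compound 2 on the carbonyl carbon in place of the 2-bromophenyl group.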